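A few compounds are considered here, and "the series" means these few. Any claim that something is new, unique, unknown or untested is made for them only; others in the source may bear on it.

Measured compounds in an assay on C6 glioma cells for displacement of a labelled ligand from sodium- and chloride-dependent glycine transporter 1 (Rattus norvegicus), read by scintillation counting, with stated times of 30 min and 10 min; a higher number here means a weaker inhibitor, a lower number a stronger inhibitor:
Compound 1 `CCc1nnc(-c2ccc(-c3ccccc3)cc2)n1-c1ccccc1C` gives 300 nM.
Compound 2 `CCc1nnc(-c2ccc(-c3ccccc3)cc2)n1-c1cccc(N)c1C` gives 320 nM.
Compound 3 `CCc1nnc(-c2ccc(-c3ccccc3)cc2)n1-c1cccc(COC)c1C` gives 2400 nM.

Compound 3 stands highest of the three numbers in this assay; the nearest is compound 2 and the furthest compound 1, both separated from it by steps beyond the scatter. The change to compound 4 `CCc1nnc(-c2ccc(-c3ccccc3)cc2)n1-c1cccc(F)c1C` is fluoro in place of methoxymethyl on an aromatic carbon. Within the data shown here, two measured steps bear on this change, as each installs the methoxymethyl group at the same aromatic carbon of the shared core: an 8.0-fold higher number from compound 1 to compound 3 (0.90 log units; beyond the scatter), and a 7.5-fold higher number from compound 2 to compound 3 (0.88 log units; beyond the scatter). Both run the other way from the step now in question, and both say that the methoxymethyl group costs roughly the same amount whether hydrogen or amino stands there instead. The comparison a 1.1-fold higher number from compound 1 to compound 2 (0.03 log units; within the scatter) shows hydrogen and amino to be interchangeable at this carbon. Fluoro carries one heavy atom and no hydrogen-bond acceptor, so it counts on the side of hydrogen and amino rather than of methoxymethyl. A step down of about the size seen in those two steps is therefore expected: a 6.9-fold lower number from compound 3 to compound 4 (0.84 log units; beyond the scatter). For compound 4 the expected value in this assay is 350 nM, with a range from 150 nM to 900 nM.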

Compound 4, half-maximal inhibitory concentration: 630 nM
Beside the measured number, compound 4's estimate is 1.8-fold (0.26 log units) below it; low and high end bracket the measured number.
By their numbers in this assay, from the lowest: compounds 1, 2 and 4 (each within the scatter of the next, the first and the last beyond it); then compound 3.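

Fluoro at this carbon, ortho to a methyl group, gives back much of what methoxymethyl costs (a 3.8-fold lower number from compound 3 to compound 4 (0.58 log units; beyond the scatter)), so in this assay the penalty seen with compound 3 does not extend to every replacement of hydrogen there. Fluoro does not fully match hydrogen, however: the modest step (a 2.1-fold higher number from compound 1 to compound 4 (0.32 log units; beyond the scatter)) lies beyond the scatter, whereas the step from amino (a 2.0-fold higher number from compound 2 to compound 4 (0.29 log units; within the scatter)) lies within it, so compounds 1, 2 and 4 form a chain of close neighbours rather than one flat level. No measurement available here accounts for either step.

The series leaves open whether the loss with methoxymethyl follows the heavy-atom count of the group or its oxygen, and a hydroxymethyl, an ethyl or a methoxy group at this carbon would help to separate the two readings. It also leaves open how far the small differences among hydrogen, amino and fluoro extend to other groups of one heavy atom, such as hydroxyl, or to chloro, which is slightly larger.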